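A few compounds are considered here, and "the series" means these few. Any claim that something is new, unique, unknown or untested is made for them only; others in the source may bear on it.

Compound 1 `Cc1nc(S(C)(=O)=O)ccc1Oc1ncnc(OC2CCN(C(=O)O[C@@H](C)CF)CC2)c1F` gives 84% in a functional assay on isolated protein for inhibition of Glucose-dependent insulinotropic receptor (Rattus norvegicus), read by HTRF and cAMP accumulation; a lower number here means a smaller maximal response, a higher number a larger maximal response. Compound 2 `CCC1(OC(=O)N2CCC(Oc3ncnc(Oc4ccc(S(C)(=O)=O)nc4C)c3F)CC2)CC1` gives 83%.

Compound 2 holds the lowest of the two numbers, with compound 1 nearest at a step within the scatter (a number 1 percentage points lower from compound 1 to compound 2 (within the scatter)). Compound 3 `Cc1nc(S(C)(=O)=O)ccc1Oc1ncnc(OC2CCN(C(=O)SC3CC3)CC2)c1F` differs from compound 2 by a group of 4 heavy atoms (3 carbon, 1 sulfur; one three-membered non-aromatic ring of carbon only) in place of a group of 6 heavy atoms (5 carbon, 1 oxygen; one three-membered non-aromatic ring of carbon only), on a carbonyl carbon. Within the data shown here, the one measured step, from compound 1 to compound 2, also exchanged the group on the carbonyl carbon, and it moved a number 1 percentage points lower from compound 1 to compound 2 (within the scatter). On that basis no step beyond the scatter in this assay is expected, so compound 3 is estimated at 82% (range 72% to 92%), a change of a number 1 percentage points lower from compound 2 to compound 3 (within the scatter).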

Compound 3, largest response reached (reported as efficacy), in percent of the reference or control that the assay uses: 80%
For compound 3 the middle estimate is 2 percentage points above the measured one; the measured number falls inside the stated range.
By their numbers in this assay, from the lowest: compounds 3, 2 and 1 (each within the scatter of the next).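

In this assay, the carbonyl carbon whose other neighbour is the amide-type nitrogen in a ring now carries a group holding sulfur, where compound 1 and compound 2 held groups with oxygen, and the result stays close, with a number 3 percentage points lower from compound 2 to compound 3 (within the scatter) and a number 4 percentage points lower from compound 1 to compound 3 (within the scatter). The position therefore accepts this exchange as well as the earlier one, with no step beyond the scatter. Nothing measured here explains this result.
On these data alone, whether an amine or a longer carbon chain on that carbonyl carbon would keep the maximal response in this range remains open.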